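Removing a methyl from a weak antiproliferative thiosemicarbazone

The source may hold more compounds than are shown below. What is called first, only, known or untested is meant among the compounds shown, and "the series" means these compounds.

Three related compounds have been tested in a functional assay on HT-29 cells (Homo sapiens) for antiproliferative activity, read by sulforhodamine B assay, with a stated time of 72 h; a lower number here means a stronger inhibitor, a higher number a weaker inhibitor. Compound 1, with structure `Cc1ccccc1NC(=S)N/N=C/c1ccc2ccccc2n1`, gives 42300 nM. Compound 2, with structure `CN(C)C(=S)N/N=C/c1ccc2cccnc2n1`, gives 410 nM. Compound 3, with structure `NC(=S)N/N=C/c1cc2cccnc2s1`, gives only a limit of the assay, > 100000 nM, so its true value is not known. Among the two numbers shown, compound 1 stands as the higher one, well above compound 2, a gap far beyond the usual scatter.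

Compound 4, with structure `S=C(N/N=C/c1ccc2ccccc2n1)Nc1ccccc1`, has not yet been measured. It differs from compound 1 in one place: hydrogen in place of methyl on an aromatic carbon. Among the compounds with values here, no step of this kind between two measured compounds is available, so only a guess is possible.

The expected step in this assay from compound 1 to compound 4 is small, a 1.1-fold lower number from compound 1 to compound 4 (0.02 log units; within the scatter), within the usual scatter and in no definite direction. Compound 4 is therefore estimated to give 40000 nM in this assay, expected to fall between 12000 nM and 130000 nM.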

Compound 4, half-maximal inhibitory concentration: 17000 nM
Beside the measured number, compound 4's estimate is 2.4-fold (0.37 log units) above it; measured number inside the range.
By their numbers in this assay, from the lowest: compound 2; then compound 4; then compound 1. At a limit, above all of these: compound 3.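

In this assay, the change from 2-methylphenyl to phenyl gives a 2.5-fold lower number from compound 1 to compound 4 (0.40 log units; beyond the scatter), so the methyl on this aromatic carbon, ortho to a large group, is not needed for the activity. Its removal brings a modest gain instead. This is the only step shown between two measured compounds that differ in one place, and it shows that the activity responds to the loss of just one carbon at this position. The data shown give no reason for this step.

From the compounds shown here alone, it remains open whether an amine, a methoxy group or a chlorine atom in this place would lower the number further or raise it. A single step also cannot show whether removing this methyl would have a similar effect on a different core.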